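This account rests on a few compounds, and the source may have more. Where it says the series, first, only, none or still open, it means among the compounds named here.

Compound 1 `Cc1ccc(OCc2cn(-c3ccc(S(=O)(=O)N4CCc5ccccc5C4)cc3)nn2)cc1` and compound 2 `O=S(=O)(c1ccc(-n2cc(COc3ccccc3)nn2)cc1)N1CCc2ccccc2C1` have both been tested in an ADME assay on Vero cells (Chlorocebus sabaeus) for cytotoxicity, with a stated time of 4 days (a lower number here means a stronger inhibitor, a higher number a weaker inhibitor), and compound 3 `O=S(=O)(c1ccc(-n2cc(CO)nn2)cc1)N1CCc2ccccc2C1` has not. Compound 1 gives > 50 ug/mL, which is a limit of the assay and not a number. Compound 2 gives > 50 ug/mL, which is likewise only a limit. The two measured compounds therefore share one reading: the limit of > 50 ug/mL in this assay, at which 2 of the 2 values shown sit.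

The change to compound 3 is hydrogen in place of phenyl on an oxygen on a saturated carbon, in words hydrogen in place of phenyl on an oxygen on a saturated carbon, or phenoxymethyl to hydroxymethyl. Going by the values given here, the only measured step, a step that the two limits leave unreadable from compound 1 to compound 2, is a different change, hydrogen in place of methyl, and gives no size to carry over. The expectation therefore rests on compound 2, whose > 50 ug/mL is a limit. The estimated step is a step that the limit leaves unreadable from compound 2 to compound 3, with no shift beyond the usual scatter expected in this assay. For compound 3 the expected value is 60 ug/mL, with an estimated range from 25 ug/mL to 120 ug/mL.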

Compound 3, half-maximal inhibitory concentration: > 50 ug/mL
Compound 3 gave a limit, no number; the forecaster's own chance of this, stated with the estimate: 80%; the middle value is on the limit's open side.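

No step among compound 1, compound 2 and compound 3 can be read in this assay, because each result is a limit of the assay and not a number: the limit of > 50 ug/mL in this assay, at which 3 of the 3 values shown sit.

The compounds shown leave open at what concentration any of them would reach half-maximal inhibition, and whether phenoxymethyl to hydroxymethyl changes that concentration at all.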